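From 2-oxopyrrolidin-1-yl to 1,3-dimethyl-1H-pyrazol-5-yl on a shared core

The compounds below may be only part of what the source reports. "The series", "measured", "known", "first", "only" and "open" are said of these compounds alone.

The account starts from compound 1 `O=C1CCCN1c1cnc(NCc2c(F)ccc3c2CCO3)c2cn[nH]c(=O)c12`. In a physicochemical assay for solubility, read by LC-MS, in phosphate buffer, with a stated time of 24 h, at pH 7.4 (a higher number here means a more soluble compound, a lower number a less soluble compound), compound 1 gives only a limit, < 2000 nM, and not a number. As far as these compounds go, its exact standing therefore remains unknown. Within the data shown here, the only numerical reading so far comes from compound 2 `CN(C)Cc1ccc(C(=O)Nc2cnc(NCc3c(F)ccc4c3CCO4)n3cnnc23)cc1`, which gives 520000 nM in this assay.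

Compound 3 `Cc1cc(-c2cnc(NCc3c(F)ccc4c3CCO4)c3cn[nH]c(=O)c23)n(C)n1` keeps the core of compound 1 and carries 1,3-dimethyl-1H-pyrazol-5-yl in place of 2-oxopyrrolidin-1-yl on an aromatic carbon. Among the measured compounds shown here, no measured pair shows what this exchange does. The expectation in this assay is therefore for no step beyond the scatter, in either direction, and another reading at the limit would not be surprising. The expected change is a step that the limit leaves unreadable from compound 1 to compound 3. For compound 3 the estimated value is 1500 nM, with an expected range from 400 nM to 8000 nM.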

Compound 3, solubility: 1000 nM
Compound 3: the middle estimate sits 1.5-fold (0.18 log units) above what was measured; the range from low to high includes it.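

No step from compound 1 to compound 3 can be read in this assay, because compound 1 gives only a limit and not a number: the limit of < 2000 nM in this assay, at which 1 of the 3 values shown sits.

The compounds shown leave open how large a step 1,3-dimethyl-1H-pyrazol-5-yl in place of 2-oxopyrrolidin-1-yl on an aromatic carbon gives.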